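The compounds below may be only part of what the source reports. "The series", "measured", "known", "first", "only" and "open" are said of these compounds alone.

The three measured compounds share one core. Compound 1 `Cc1ccc(NC(=O)Nc2nc(Nc3ccccc3)cc(Sc3c[nH]c4ccccc34)n2)cc1` gives 14900 nM in a functional assay on HepG2 cells (Homo sapiens) for inhibition, with a stated time of 72 h; on this read-out higher numbers stand for weaker inhibition and lower numbers for stronger inhibition. Compound 2 `O=C(Nc1ccccc1)Nc1nc(Sc2c[nH]c3ccccc23)cc(N2CCN(Cc3ccccc3)CC2)n1` gives 8160 nM in this assay, and compound 3 `O=C(Nc1ccc(Cl)cc1)Nc1nc(Sc2c[nH]c3ccccc23)cc(N2CCCC2)n1` gives 7870 nM in this assay. On the numbers as written, compound 3 sits at the low end of the three, yet its gap to compound 2 and its gap to compound 1 both lie within the scatter, so the three compounds cannot be told apart on this read-out.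

Compound 4 `O=C(Nc1ccccc1)Nc1nc(Sc2c[nH]c3ccccc23)cc(N2CCCC2)n1` has not yet been measured. It differs from compound 3 in one place: hydrogen in place of chloro on an aromatic carbon, that is, 4-chlorophenyl becomes phenyl on the aryl urea. For the measured compounds named here, no pair of measured compounds differs in a single place, so no measured step shows how this core answers to such a change, and the expectation rests on the change alone. The step from compound 3 to compound 4 in this assay is expected to be small, leaning if anything toward a higher number, and not beyond the scatter. Compound 4 is therefore estimated at 10500 nM in this assay, with a range from 4500 nM to 25000 nM. This estimate corresponds to an expected step of a 1.3-fold higher number from compound 3 to compound 4 (0.13 log units; within the scatter).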

Compound 4, half-maximal inhibitory concentration: 11400 nM
Estimate against measurement, compound 4: 1.1-fold (0.04 log units) below; the measured number falls inside the stated range.
By their numbers in this assay, from the lowest: compounds 3, 2, 4 and 1 (each within the scatter of the next).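

For the compounds shown here, compound 3 and compound 4 give the first comparison on the shared core that differs in one place: in this assay, hydrogen in place of chloro on the aromatic carbon of the 4-chlorophenyl group gives a 1.4-fold higher number from compound 3 to compound 4 (0.16 log units; within the scatter), so the step cannot be told apart from repeated measurement. On this read-out and with the rest of compound 3 held fixed, the phenyl urea therefore serves as well as the 4-chlorophenyl urea as far as can be seen, and the chloro is not shown to be needed for the inhibition recorded. Nothing measured here bears on why this change makes so little difference.

From the compounds shown here alone, whether any other group on this aromatic carbon, such as a methoxy group, an amine or a carboxylic acid, would move the number beyond the scatter remains open. Going by these compounds alone, it is also open whether the same change from chloro to hydrogen would read the same way with a different group in the place of the one carried by compound 3 and compound 4, such as the anilino group of compound 1.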